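Methoxy additions on a shared indole-type scaffold with nitrile acceptors

The source may report more compounds than this note shows. Statements on the series, on what has been measured and on what is new or still open speak of the compounds shown alone.

Compound 1 `COc1ccc(-c2[nH]c3ccccc3c2/C=C(\C#N)S(=O)(=O)c2ccccc2)cc1` gives 200 nM in a functional assay on MT4 cells (Homo sapiens) for antiproliferative activity, read by MTT assay, with a stated time of 96 h; a higher number here means that more compound is needed for the effect, a lower number that less compound is needed. Compound 3 `COc1ccc(-c2[nH]c3ccc(OC)cc3c2/C=C(\C#N)S(=O)(=O)c2ccccc2)cc1` gives 200 nM in this assay and carries methoxy in place of hydrogen on an aromatic carbon, and the step of no change at the digits printed from compound 1 to compound 3 (within the scatter) shows that this addition leaves the read-out where it was. Compound 2 `COc1ccc2[nH]c(-c3ccccc3)c(C=C(C#N)C#N)c2c1` gives 1000 nM in this assay; the difference between the core of compound 2 and the core of compound 1 is not broken down here. Compound 4 `COc1ccc(-c2[nH]c3ccc(OC)cc3c2C=C(C#N)C#N)cc1` differs from compound 2 by methoxy in place of hydrogen on an aromatic carbon, which reads as phenyl to 4-methoxyphenyl. This is the same kind of change as from compound 1 to compound 3, but the place differs: there the methoxy sits on a ring of a fused system, here on a single six-membered ring, para to a large group. Because the measured step of no change at the digits printed from compound 1 to compound 3 (within the scatter) is flat, the step of no change at the digits printed from compound 2 to compound 4 (within the scatter) is expected to be small as well. Compound 4 is estimated at 1000 nM in this assay.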

Compound 4, half-maximal effective concentration: 300 nM
Compound 4: the middle estimate sits 3.3-fold (0.52 log units) above what was measured; the measured number lies below the stated range.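

Phenyl to 4-methoxyphenyl gives a 3.3-fold lower number from compound 2 to compound 4 (0.52 log units; beyond the scatter) in this assay, so methoxy in place of hydrogen on an aromatic carbon does not carry over at a fixed size from one core to the other: the same change on two cores in this assay, no change at the digits printed (within the scatter) from compound 1 to compound 3 and a 3.3-fold lower number (0.52 log units; beyond the scatter) from compound 2 to compound 4, 3.3-fold (0.52 log units) apart, beyond the scatter of two such steps

The two steps differ in the core and also in the place of the methoxy, on a ring of a fused system in one and on a single six-membered ring in the other, so the gap cannot be assigned to either difference. With one pair per core, the result gives neither a rule for further cores nor a cause.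

On these data alone, whether an amine, a carboxylic acid or a longer alkoxy chain in the same place would move the read-out remains open. So does the effect of each methoxy alone on the core of compound 2.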